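Nitro for fluoro on a series at the assay limit

The compounds below may be only part of what the source reports. "The series", "measured", "known", "first", "only" and "open" are said of these compounds alone.

Compound 3 `Fc1ccc(-c2nc3sc(Cc4ccc(Cl)cc4)nn3c2Br)cc1` stands at a limit rather than a number: in a functional assay on HeLa cells (Homo sapiens) for cytotoxicity, with a stated time of 72 h (on this read-out lower numbers stand for stronger inhibition and higher numbers for weaker inhibition), compound 3 gives > 250000 nM. Compound 1 `Fc1ccc(-c2cn3nc(Cc4ccc(Cl)cc4)sc3n2)cc1` likewise reaches only a limit, > 250000 nM. Compound 2 `Clc1ccc(Cc2nn3cc(-c4ccccc4)nc3s2)cc1` also returns only a limit, > 250000 nM. The change to compound 4 `O=[N+]([O-])c1ccc(-c2nc3sc(Cc4ccc(Cl)cc4)nn3c2Br)cc1` is nitro in place of fluoro on an aromatic carbon. The two steps measured on the shared core, a step that the two limits leave unreadable from compound 1 to compound 2 and a step that the two limits leave unreadable from compound 1 to compound 3, are both unreadable, since (the limit of > 250000 nM in this assay, at which 3 of the 3 values shown sit). Among the measured compounds shown here, no measured step therefore sets a size or direction for the change in this assay, and nothing indicates that the nitro group would bring the read-out under the limit. Compound 4 is expected to stay at the limit, with an estimate of 300000 nM and a range from 100000 nM to 1000000 nM, a step that the limit leaves unreadable from compound 3 to compound 4.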

Compound 4, half-maximal inhibitory concentration: > 250000 nM
Compound 4: only a limit was reported; the forecaster's own chance of this, stated with the estimate: 85%; the middle value does not contradict the limit.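

In this assay, no new step can be read between compound 3 and compound 4, since both stand only at a limit: the limit of > 250000 nM in this assay, at which 4 of the 4 values shown sit.

The compounds shown leave open whether any change on the shared core gives a measurable value.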